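Carbonyl Substituent Exchange in a Growth Inhibition Series

This account rests on a few compounds, and the source may have more. Where it says the series, first, only, none or still open, it means among the compounds named here.

Compound 1 `COc1cc(-c2nn(-c3cccc(NC(=O)c4cccc(C(F)(F)F)c4)c3)cc2-c2ccncc2)ccc1Cl` was measured in a functional assay on HCT-15 cells (Homo sapiens) for inhibition, read by sulforhodamine B assay, with a stated time of 48 h (a lower number here means a stronger inhibitor of growth, a higher number a weaker inhibitor of growth), and gives 1550 nM. Within the data shown here, of the two compounds with numbers so far, compound 1 stands highest. Compound 2 `O=C(Nc1cccc(-n2cc(-c3ccncc3)c(-c3ccc(Cl)c(O)c3)n2)c1)Nc1cc(C(F)(F)F)cc(C(F)(F)F)c1` differs from compound 1 in more than one place; in this assay compound 2 gives 474 nM, a number beyond the scatter below that of compound 1. Compound 3 `COc1cc(-c2nn(-c3cccc(NC(=O)Nc4ccc(Cl)c(C(F)(F)F)c4)c3)cc2-c2ccncc2)ccc1Cl` is not yet measured; it differs from compound 1 by (4-chloro-3-(trifluoromethyl)phenyl)amino in place of 3-(trifluoromethyl)phenyl on a carbonyl carbon. Among the measured compounds shown here, no measured pair differs in only one place, so the size of this kind of step is not known. Because compound 2 gives 474 nM while carrying a carbonyl bearing an amino group, a downward step beyond the scatter is expected from compound 1 to compound 3, estimated as a 3.1-fold lower number from compound 1 to compound 3 (0.49 log units; beyond the scatter). Compound 3 is expected to give about 500 nM in this assay, with an estimated range from 150 nM to 1600 nM.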

Compound 3, concentration for 50% growth inhibition: 1230 nM
For compound 3 the middle estimate is 2.5-fold (0.39 log units) below the measured one; measured number inside the range.
By their numbers in this assay, from the lowest: compound 2; then compounds 3 and 1 (each within the scatter of the next).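

Among these compounds, this is the first single-place step: in this assay, (4-chloro-3-(trifluoromethyl)phenyl)amino in place of 3-(trifluoromethyl)phenyl on a carbonyl carbon gives a 1.3-fold lower number from compound 1 to compound 3 (0.10 log units; within the scatter). At this position, the entering group brings an amino nitrogen, a chlorine and a hydrogen-bond donor, yet the numbers for compound 1 and compound 3 stay within the scatter of each other. No measured property is available that bears on this result.

The amino nitrogen and the chlorine enter together, so their separate effects cannot be read, and the number for compound 2, which differs from compound 1 in more than one place, cannot be tied to any single difference. Also open, from the compounds shown here alone, is how a morpholine or a longer alkyl chain on this carbonyl carbon would read in this assay.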